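The source may report more compounds than this note shows. Statements on the series, on what has been measured and on what is new or still open speak of the compounds shown alone.

Compound 1 `N=C(NCCCc1c[nH]cn1)NCCC(c1cccc(C(F)(F)F)c1)c1ccccn1` is a full agonist in a functional assay on cardiac atrium for agonist activity at histamine H2 receptor (Cavia porcellus); on this read-out higher numbers stand for larger maximal responses and lower numbers for smaller maximal responses: compound 1 gives 1. Compound 2 `N=C(NCCCc1c[nH]cn1)NCCC(c1cc(F)cc(F)c1)c1ccccn1` in this assay gives 1, and no change at the digits printed from compound 1 to compound 2 (within the scatter) is a step that lies within the scatter. On these numbers compound 2 stands level with compound 1. Compound 3 `N=C(NCCCc1c[nH]cn1)NCCC(c1ccccn1)c1cccs1` differs from compound 2 by thiophen-2-yl in place of 3,5-difluorophenyl on a saturated chain carbon bound to an aromatic carbon and a saturated chain carbon. Going by the values given here, the only step measured, from compound 1 to compound 2, exchanged the group at the same place without moving this assay; no step beyond the scatter is expected here, a number 0.050 lower from compound 2 to compound 3 (within the scatter). Compound 3 is therefore expected at 0.95, within 0.8 to 1.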

Compound 3, intrinsic activity: the largest response reached, as a fraction of the reference agonist's: 1
Estimate against measurement, compound 3: 0.050 below, within the range that was stated.
By their numbers in this assay, from the lowest: compounds 1, 2 and 3 (each within the scatter of the next).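

The saturated chain carbon bound to an aromatic carbon and a saturated chain carbon now accepts a five-membered aromatic ring with 1 hetero atom, not only a six-membered aromatic ring of carbon only: this assay shows no change at the digits printed from compound 2 to compound 3 (within the scatter) and no change at the digits printed from compound 1 to compound 3 (within the scatter). Nothing available explains this result. On these data alone, whether an amine or a carboxylic acid at this place would keep the maximal response remains open, as does the effect of a longer chain.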